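Swapping cyclohexyl for tert-butyl: compound 3 to compound 4

The compounds below may be only part of what the source reports. "The series", "measured", "known", "first", "only" and "open" are said of these compounds alone.

Compound 1 `C#CCO/C=C/C(=O)OC` gives in a functional assay on HBL-100 cells (Homo sapiens) for antiproliferative activity, read by sulforhodamine B assay, with a stated time of 48 h (on this read-out lower numbers stand for stronger inhibition of growth and higher numbers for weaker inhibition of growth), only a limit, > 100000 nM. Compound 2 `CC1CCC(C(C)C)C(OC(=O)C#CC(O/C=C/C(=O)OC2CC(C)CCC2C(C)C)C(C)C)C1` likewise gives only a limit in this assay, > 100000 nM. Compounds 1 and 2 thus both sit at the limit of > 100000 nM in this assay, at which 2 of the 3 values shown sit. Among the measured compounds shown here, compound 3 `COC(=O)C#CC(O/C=C/C(=O)OC)C1CCCCC1` is the single member of the three with a number in this assay, where compound 3 gives 2500 nM. For the measured compounds named here, it stands alone among the values shown, with no second number to rank it against and no step between measured compounds to draw on.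

Compound 4 `COC(=O)C#CC(O/C=C/C(=O)OC)C(C)(C)C` differs from compound 3 in one place: tert-butyl in place of cyclohexyl on a saturated chain carbon bound to an oxygen on an unsaturated carbon and a triple-bonded carbon. Going by the values given here, no measured step touches that change, so its size is open. The expectation is a step in this assay from compound 3 to compound 4 that stays within the usual scatter or runs only slightly toward weaker inhibition of growth, a 1.6-fold higher number from compound 3 to compound 4 (0.20 log units; within the scatter). Compound 4 is accordingly estimated in this assay at 4000 nM, with a range from 1000 nM to 20000 nM wide enough to hold a modest shift in either direction.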

Compound 4, concentration for 50% growth inhibition: 1800 nM
Compound 4: the middle estimate sits 2.2-fold (0.35 log units) above what was measured, within the range that was stated.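

Among the compounds shown here, with tert-butyl in place of cyclohexyl on a saturated chain carbon bound to an oxygen on an unsaturated carbon and a triple-bonded carbon, this assay gives a 1.4-fold lower number from compound 3 to compound 4 (0.14 log units; within the scatter), so this pair carries no order and gives the series its only readable step. At this position, the six-membered carbon ring is therefore not required for a number in this range, since compound 4 has no ring and still gives a value within the scatter of that of compound 3, although this rests on a single pair and two groups with only carbon atoms. Nothing measured here gives a cause for this result.

Steps to compound 1 and compound 2 cannot be read, as neither differs from the others in one place and both values are limits of the assay: the limit of > 100000 nM in this assay, at which 2 of the 4 values shown sit. Whether an amine, a carboxylic acid, a phenyl ring or a longer chain at this same position keeps a number in this range stays open, as does any change elsewhere on the shared core.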